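A few compounds are considered here, and "the series" means these few. Any claim that something is new, unique, unknown or untested is made for them only; others in the source may bear on it.

Measured so far in a functional assay on MCF7 cells (Homo sapiens) for inhibition; a higher number here means a weaker inhibitor, a lower number a stronger inhibitor:
- compound 1, `CC/C(=C(/c1ccc(/C=C/C(=O)O)cc1)c1cc2ccccc2[nH]1)c1ccccc1OC(F)(F)F`: 206 nM
- compound 2, `CC/C(=C(/c1ccc(/C=C/C(=O)O)cc1)c1cc2ccccc2[nH]1)c1cccc(OC(F)(F)F)c1`: 282 nM

Going by the values given here, compound 2 sits at one end of this pair of numbers, but its only neighbour is compound 1 and the step of a 1.4-fold higher number from compound 1 to compound 2 (0.14 log units; within the scatter) lies within the scatter, so the two are not separated by this assay.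

Compound 3, `CC/C(=C(/c1ccc(/C=C/C(=O)O)cc1)c1cc2ccccc2[nH]1)c1ccc(OC)cc1`, differs from compound 2 by 4-methoxyphenyl in place of 3-(trifluoromethoxy)phenyl on a double-bonded chain carbon bound to a double-bonded chain carbon and a saturated chain carbon. Among the compounds with values here, the single measured step, a 1.4-fold higher number from compound 1 to compound 2 (0.14 log units; within the scatter), concerns the same aryl group and bears on the question only loosely: it moves the trifluoromethoxy group from one position to another and does not exchange it for a methoxy group, and no measured step makes that exchange. Within the data shown here, with the one relevant step within the scatter, no change beyond the scatter is expected in this assay. Compound 3 is therefore estimated at 250 nM, with a range of 90 nM to 700 nM, which amounts to an expected step of a 1.1-fold lower number from compound 2 to compound 3 (0.05 log units; within the scatter).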

Compound 3, half-maximal inhibitory concentration: 61 nM
Beside the measured number, compound 3's estimate is 4.1-fold (0.61 log units) above it; the measured number lies below the stated range.
By their numbers in this assay, from the lowest: compound 3; then compounds 1 and 2 (each within the scatter of the next).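

In this assay, the steps of a 4.6-fold lower number from compound 2 to compound 3 (0.66 log units; beyond the scatter) and a 3.4-fold lower number from compound 1 to compound 3 (0.53 log units; beyond the scatter) both lie beyond the scatter, so the aryl group on this double-bonded chain carbon can change the number measurably. The two trifluoromethoxy compounds alone gave no such separation, whereas 4-methoxyphenyl stands apart from both with the lower number. No available measurement speaks to the origin of this step.

On these data alone, the exchange alters the substituent and its ring location together, so it remains open whether the methoxy group, its location on the ring, or the combination accounts for the lower number. As far as these compounds go, how an ethoxy group or an amine in place of the methoxy group on this aryl ring would read in this assay also remains open.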